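The source may report more compounds than this note shows. Statements on the series, on what has been measured and on what is new or still open speak of the compounds shown alone.

Measured so far:
- compound 1, `Cn1c(-c2ccc(NC(=O)CN3CCN(c4ccccc4)CC3)cc2)nc2cc(C(F)(F)F)ccc21`: 1500 nM
- compound 2, `Cn1c(-c2ccc(N)cc2)nc2cc(C(F)(F)F)ccc21`: 20000 nM
- compound 3, `O=[N+]([O-])c1ccc(-c2nc3ccccc3[nH]2)c([N+](=O)[O-])c1`: 7000 nM

In an ADME assay on MT4 cells (Homo sapiens) for cytotoxicity, read by MTT assay, with a stated time of 96 h (on this read-out lower numbers stand for higher toxicity in this test and higher numbers for lower toxicity in this test), compound 3 gives 7000 nM, which puts it second highest of the three numbers. Its nearest neighbour is compound 2, whose value lies higher by a margin beyond the scatter; compound 1 lies furthest from it, lower by a wider margin that is also beyond the scatter. Compound 3 therefore sits between the two, closer to the less toxic end than to compound 1.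

The compound that follows is compound 4, `O=[N+]([O-])c1ccccc1-c1nc2ccccc2[nH]1`, which has not yet been tested in this assay. Compared with compound 3 it differs in one place: hydrogen in place of nitro on an aromatic carbon. One nitro group is removed from the six-membered aromatic ring of carbon only, while the remaining nitro group and the group of 9 heavy atoms stay where they are.

Within the data shown here, no pair of measured compounds shows this change, so there is no step to lean on. The change is small in atoms, and the step is expected to be modest, with a somewhat higher number for compound 4, though possibly none beyond the scatter. The step from compound 3 to compound 4 is expected to be a 1.4-fold higher number from compound 3 to compound 4 (0.15 log units; within the scatter). For compound 4 the expected value in this assay is 10000 nM, with a range from 3000 nM to 40000 nM.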

Compound 4, half-maximal cytotoxic concentration: 60000 nM
For compound 4 the middle estimate is 6.0-fold (0.78 log units) below the measured one, and the stated range ends below it.
By their numbers in this assay, from the lowest: compound 1; then compound 3; then compound 2; then compound 4.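

In this assay, the change from nitro to hydrogen on an aromatic carbon, para to a group of 9 heavy atoms and meta to a nitro group, gives an 8.6-fold higher number from compound 3 to compound 4 (0.93 log units; beyond the scatter), a step well beyond the scatter. Among these compounds, this is the first step that can be read at a single place, and it shows that this position on the six-membered aromatic ring of carbon only is not indifferent to what it carries: the number is lower with the nitro group, which stands for higher toxicity in this test, and higher with hydrogen. Nothing available accounts for the size of this step, which rests on one pair of compounds only.

On these data alone, it remains open whether another group at this place, such as an amine, a methoxy group or a chlorine atom, would keep the number of compound 3, reach that of compound 4, or fall elsewhere. As far as these compounds go, it is equally open whether replacing the remaining nitro group of compound 4 with hydrogen would move the number further, and in which direction.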